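The source may report more compounds than this note shows. Statements on the series, on what has been measured and on what is new or still open speak of the compounds shown alone.

In a functional assay on PC-3 cells (Homo sapiens), read by MTT assay, with a stated time of 48 h (a higher number here means a weaker inhibitor, a lower number a stronger inhibitor), compound 1 (`CCN(CC)CCNC(=O)c1ccc(C(CC)(CC)c2ccc(OCC(O)C(C)(C)C)c(C)c2)n1CC`) gives 220 nM while compound 2 (`C#CC(C)OC(=O)c1ccc(C(CC)(CC)c2ccc(OCC(O)C(C)(C)C)c(C)c2)n1CC`) gives 38200 nM and so holds the higher of the two numbers, the weaker end of what has been measured. Compound 3 (`CCn1c(C(=O)OCc2ccc(F)cc2)ccc1C(CC)(CC)c1ccc(OCC(O)C(C)(C)C)c(C)c1`) departs from compound 2 in one place, on an oxygen next to a carbonyl group, where 4-fluorobenzyl stands in place of 1-methylprop-2-yn-1-yl (4-fluorobenzyl in place of 1-methylprop-2-yn-1-yl on an oxygen next to a carbonyl group). Among the compounds with values here, only one measured step bears on this, and only loosely: the large change (a 170-fold higher number from compound 1 to compound 2 (2.24 log units; beyond the scatter)) that came with (1-methylprop-2-yn-1-yl)oxy in place of (2-(diethylamino)ethyl)amino on a carbonyl carbon. Within the data shown here, compound 3 also lacks that (2-(diethylamino)ethyl)amino group, and no measured step compares two groups on this oxygen. Compound 3 is therefore expected to stay close to compound 2 rather than approach compound 1. The expected change (a 1.4-fold lower number from compound 2 to compound 3 (0.13 log units; within the scatter)) is none beyond the scatter in this assay and leans only slightly toward a lower number. Compound 3 is estimated at 28000 nM with an expected range of 9000 nM to 80000 nM on the same read-out.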

Compound 3, half-maximal inhibitory concentration: > 50000 nM
Compound 3 ended at the assay's limit; the forecaster's own chance of this, stated with the estimate: 15%; middle value at least 1.7-fold (0.25 log units) from the limit.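

Compound 3 stands at a limit of this assay, > 50000 nM, which is a bound and not a number. Placing 4-fluorobenzyl in place of 1-methylprop-2-yn-1-yl on an oxygen next to a carbonyl group gives an at least 1.3-fold higher number from compound 2 to compound 3 (0.11 log units; that floor lies within the scatter), so the floor of this change does not separate the two groups, and its true size remains unknown. What is new comes from the other comparison, (4-fluorobenzyl)oxy in place of (2-(diethylamino)ethyl)amino on a carbonyl carbon, which gives an at least 220-fold higher number from compound 1 to compound 3 (2.35 log units; beyond the scatter): the large gap first seen with (1-methylprop-2-yn-1-yl)oxy returns with a group that carries an aromatic ring, and no compound shown goes against this.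

Still open, going by these compounds, is which part of the (2-(diethylamino)ethyl)amino group goes with the lower number of compound 1, since an amide with a plain ethyl chain and no diethylamino end, or a (2-(diethylamino)ethyl)oxy group on the same carbonyl carbon, would pull the amide link and the amine apart. On these data alone, how a free carboxylic acid at this place would read in this assay also remains open.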